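A few compounds are considered here, and "the series" means these few. Any claim that something is new, unique, unknown or untested is made for them only; others in the source may bear on it.

Measured in an ADME assay on MT4 cells (Homo sapiens) for cytotoxicity, read by MTT assay, with a stated time of 4 days; a lower number here means that less compound is tolerated, a higher number that more compound is tolerated:

- Compound 1 `CC(C)N(C)c1nc(Cc2c(F)cccc2F)cc(=O)[nH]1`: 85000 nM
- Compound 2 `Cc1c(Cc2c(F)cccc2F)nc(N(C)c2ccccc2)[nH]c1=O`: > 73000 nM

Cell-toxicity figures like these show how much compound cells tolerate, so a high figure is the desirable end. Compound 2 has no exact number. Its entry of > 73000 nM is a limit of the assay, so the true position of compound 2 is not known.

The next compound, compound 3 `Cc1c(Cc2c(F)cccc2F)nc(N2CCCCCC2)[nH]c1=O`, keeps the core of compound 2 and has azepan-1-yl in place of methyl(phenyl)amino on an aromatic carbon, between two ring nitrogen atoms (azepan-1-yl in place of methyl(phenyl)amino on an aromatic carbon). Within the data shown here, no measured pair shows what such a swap does. Among the measured compounds shown here, the only exact number to lean on is from compound 1, at 85000 nM, so a similarly high tolerance is the reasonable expectation.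

In this assay, the expected change is small and downward, and it may not go beyond the usual scatter: an at least 1.4-fold lower number from compound 2 to compound 3 (0.16 log units; that floor lies within the scatter). The estimated value for compound 3 is 50000 nM, with an expected range from 15000 nM to 100000 nM.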

Compound 3, half-maximal cytotoxic concentration: > 75000 nM
Compound 3 was reported as a limit; the forecaster's own chance of this, stated with the estimate: 45%; middle value at least 1.5-fold (0.17 log units) from the limit.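

In this assay compound 3 gives > 75000 nM, which is a limit and not a number. Compound 2 is also known only as a limit, and no step can be read from compound 2 to compound 3. From the compounds shown here alone, the true values of both compounds remain open, as does whether azepan-1-yl in place of methyl(phenyl)amino changes cell tolerance at all.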